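The compounds below may be only part of what the source reports. "The series", "measured", "known", "first", "only" and "open" are said of these compounds alone.

Of the compounds shown here, three share one core and have been tested in a functional assay on HT-29 cells (Homo sapiens) for inhibition; a lower number here means a stronger inhibitor, a higher number a weaker inhibitor. Compound 1 `COc1c(C)cnc(CN2CC(=O)N(CCCC(C)C)c3c(Cl)nc(N)nc32)c1C` gives 2260 nM in this assay, the highest number of the three. Compound 2 `COc1c(C)cnc(CN2c3nc(N)nc(Cl)c3NC(=O)[C@@H]2C(C)C)c1C` gives 1060 nM in this assay, a smaller number than compound 1 and beyond the usual scatter. Compound 3 `COc1ccnc(CN2CC(=O)N(CC(C)C)c3c(Cl)nc(N)nc32)c1OC` gives 40 nM in this assay, far smaller than the number of compound 1. Compound 3, however, differs from compound 1 in more than one place, so what any single change contributes cannot be read from these three numbers alone.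

Compound 4 `COc1c(C)cnc(CN2CC(=O)N(C3CCCC3)c3c(Cl)nc(N)nc32)c1C` has not yet been tested in this assay. It differs from compound 1 in one place: cyclopentyl in place of 4-methylpentyl on an amide-type nitrogen in a ring. Among the measured compounds shown here, no measured pair shows this exact change, so the expectation rests only on the spread seen so far. A modest step toward a lower number is expected from compound 1 to compound 4, a 2.5-fold lower number from compound 1 to compound 4 (0.40 log units; beyond the scatter), but it may well fall within the scatter. Compound 4 is estimated at 900 nM in this assay, within a range from 200 nM to 3500 nM.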

Compound 4, half-maximal inhibitory concentration: 330 nM
Compound 4: the middle estimate sits 2.7-fold (0.44 log units) above what was measured; low and high end bracket the measured number.
By their numbers in this assay, from the lowest: compound 3; then compound 4; then compound 2; then compound 1.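

In this assay, among the compounds shown here, putting cyclopentyl in place of 4-methylpentyl on the amide-type nitrogen gives a 6.8-fold lower number from compound 1 to compound 4 (0.84 log units; beyond the scatter) and is the first single-place change that can be read directly. It shows that the number responds to the group at this position, even though neither group carries a hydrogen-bond donor, a hydrogen-bond acceptor or a net charge. No measurement at hand explains the drop. Going by these compounds, whether the closed ring matters, or only the change in chain size, remains open; a straight pentyl chain or a cyclohexyl ring on the same nitrogen would be needed to separate the two. Also open, on these data alone, is how this position would respond to a group holding an amine or an ether oxygen.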